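Swapping Chloro for Amino on a Weak Antiproliferative Core

The source may report more compounds than this note shows. Statements on the series, on what has been measured and on what is new or still open speak of the compounds shown alone.

Within the data shown here, compound 2 `Nc1nn(C(=O)Nc2ccc(Cc3ccccc3)cc2)c2ccc(Cl)cc12` carries a chloro group on its shared core and, in a functional assay on HCT-116 cells (Homo sapiens) for antiproliferative activity, read by sulforhodamine B assay, with a stated time of 48 h (a lower number here means that less compound is tolerated, a higher number that more compound is tolerated), compound 2 gives 77200 nM, the only plain number among the values measured so far. Compound 1 `Nc1nn(C(=O)Nc2ccc(Cc3ccccc3)cc2)c2ccccc12` lacks that chloro group; in this assay compound 1 gives > 100000 nM, which is a limit of the assay rather than a number (the limit of > 100000 nM in this assay, at which 1 of the 2 values shown sits). The step of an at least 1.2-fold lower number from compound 1 to compound 2 (0.11 log units; that floor lies within the scatter) is therefore known only as a floor. Compound 3 `Nc1ccc2c(c1)c(N)nn2C(=O)Nc1ccc(Cc2ccccc2)cc1` differs from compound 2 by amino in place of chloro on an aromatic carbon. Among the measured compounds shown here, the single measured step bears on this change only loosely: it shows that a substituent on that aromatic carbon can move the number at least a little, but says nothing about an amino group. The expected step of a 1.2-fold higher number from compound 2 to compound 3 (0.07 log units; within the scatter) is accordingly small, with no clear direction beyond the scatter. For compound 3 the estimate in this assay is 90000 nM, ranging from 35000 nM to 250000 nM.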

Compound 3, concentration lethal to 50% of the cells: 50000 nM
Estimate against measurement, compound 3: 1.8-fold (0.26 log units) above, within the range that was stated.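

Amino and chloro on this aromatic carbon cannot be told apart in this assay, since the swap gives a 1.5-fold lower number from compound 2 to compound 3 (0.19 log units; within the scatter) and so adds no clear change. Against hydrogen on the same carbon, the result is an at least 2.0-fold lower number from compound 1 to compound 3 (0.30 log units; that floor lies within the scatter) and is again only a floor, one that still does not pass the scatter. As far as these compounds go, compound 1 stands at a limit of the assay rather than at a number, and the full size of this step stays unknown because of that limit: the limit of > 100000 nM in this assay, at which 1 of the 3 values shown sits.

From the compounds shown here alone, it remains open whether a different group on this carbon, such as a methoxy group, a carboxylic acid or a longer chain, would move the number beyond the scatter. Going by these compounds, it also remains open whether any such group could bring the number well below those seen so far on the shared core.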